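The source may report more compounds than this note shows. Statements on the series, on what has been measured and on what is new or still open speak of the compounds shown alone.

Measured so far:
Compound 1, `CCN(C)C(=O)c1sc(-c2ccccc2)nc1O`: 6400 nM
Compound 2, `CCOC(=O)c1sc(-c2ccccc2)nc1O`: 32 nM

Among the measured compounds shown here, in an assay on HEK293 cells for inhibition of transient receptor potential cation channel subfamily M member 8 (Homo sapiens), read by FLIPR, with stated times of 5 min and 3 min (a lower number here means a stronger inhibitor, a higher number a weaker inhibitor), compound 2 gives 32 nM, the lowest of the two numbers; its only neighbour is compound 1, which gives 6400 nM. For the measured compounds named here, the single measured step, a 200-fold lower number from compound 1 to compound 2 (2.30 log units; beyond the scatter), shows that what sits on the carbonyl carbon has a strong hold on the readout. Compound 3, `O=C(O)c1sc(-c2ccccc2)nc1O`, differs from compound 2 by hydrogen in place of ethyl on an oxygen next to a carbonyl group. Going by the values given here, no measured step touches this oxygen, so the step from compound 1 to compound 2 bears on it only as a sign that this part of the molecule is sensitive, not as a guide to direction. A change at a sensitive position is expected to move the number, and the estimated step is a 16-fold higher number from compound 2 to compound 3 (1.19 log units; beyond the scatter), towards a higher number with wide uncertainty. Compound 3 is expected to give about 500 nM, within 50 nM to 5000 nM.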

Compound 3, half-maximal inhibitory concentration: > 100000 nM
Compound 3 was reported as a limit; the forecaster's own chance of this, stated with the estimate: 15%; at least 200-fold (2.30 log units) between middle value and limit.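

Hydrogen in place of ethyl on an oxygen next to a carbonyl group gives the first reading of this oxygen, and the ethoxycarbonyl to carboxy change costs far more than the opening step gained, with an at least 3100-fold higher number from compound 2 to compound 3 (3.49 log units; beyond the scatter). Hydroxy also ranks behind ethyl(methyl)amino on the carbonyl carbon, with an at least 15-fold higher number from compound 1 to compound 3 (1.19 log units; beyond the scatter), so the three groups fall in the order ethoxy, ethyl(methyl)amino, hydroxy, from lowest number to highest. In this assay compound 3 gives > 100000 nM, which is a limit and not a number, so both steps are minimum sizes: the limit of > 100000 nM in this assay, at which 1 of the 3 values shown sits.

The compounds shown leave open whether the ethyl chain itself matters, as a methyl or a longer chain such as butyl on this oxygen would tell. They also leave open how an unsubstituted amine on the carbonyl carbon would compare.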